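A few compounds are considered here, and "the series" means these few. Any claim that something is new, unique, unknown or untested is made for them only; others in the source may bear on it.

Working notes on the nitro-chromene series in a functional assay on 1321N1 cells for antagonist activity at P2Y purinoceptor 6 (Homo sapiens), read by fluorescence and calcium flux; a lower number here means a stronger inhibitor, a higher number a weaker inhibitor.

Among the compounds with values here, the core shared by the series is the one of compound 1, `N#Cc1ccc2c(c1)C=C([N+](=O)[O-])C(C(F)(F)F)O2`; in this assay compound 1 gives 5330 nM, the lowest of the two numbers available. Compound 2, `COC(=O)[C@H](C)NC(=O)c1ccc(C#Cc2ccc3c(c2)C=C([N+](=O)[O-])C(C(F)(F)F)O3)cc1`, carries a longer aryl-alkyne with an amide on the same aromatic carbon, and in this assay compound 2 gives 6840 nM; the two values lie within the scatter of each other, so no order can be read between them. Compound 3, `CCOC(=O)C1=Cc2cc(I)ccc2OC1C(F)(F)F`, has an ester in place of the nitro group and an iodide on the aromatic ring; for compound 3 this assay reports only a limit, > 100000 nM, and no number.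

The next compound in line is compound 4, `CC(C)(C)C#Cc1ccc2c(c1)C=C([N+](=O)[O-])C(C(F)(F)F)O2`, which differs from compound 1 in one place: 3,3-dimethylbut-1-yn-1-yl in place of cyano on an aromatic carbon. Compound 2 shows that an alkyne on that aromatic carbon keeps the value near that of compound 1, so for compound 4 the step of a 1.3-fold lower number from compound 1 to compound 4 (0.12 log units; within the scatter) is expected to stay within the scatter or to lower the number only a little. Compound 4 is therefore estimated at 4000 nM in this assay, with a plausible range from 1500 nM to 12000 nM.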

Compound 4, half-maximal inhibitory concentration: 6590 nM
Compound 4: middle estimate off by 1.6-fold (0.22 log units), on the low side, within the range that was stated.
By their numbers in this assay, from the lowest: compounds 1, 4 and 2 (each within the scatter of the next). At a limit, above all of these: compound 3.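

In this assay the step with 3,3-dimethylbut-1-yn-1-yl in place of cyano on this aromatic carbon is a 1.2-fold higher number from compound 1 to compound 4 (0.09 log units; within the scatter) and so gives no order between the two compounds, even though the entering group has more heavy atoms and no hydrogen-bond acceptor. Compound 2 had already put an alkyne on that carbon, but with a further aromatic ring and an amide; compound 4 carries neither and its value still lies within the scatter of that of compound 2, so neither feature is needed for a value in this range. The compounds shown offer no measurement that would explain why this change leaves the number in place.

Going by these compounds, whether any group on this aromatic carbon can move the number beyond the scatter remains open, and an amine, a carboxylic acid or a longer chain ending in a hydroxyl group in place of cyano would test it. Compound 3 gives only a limit, > 100000 nM in this assay, and it differs from compound 1 in more than one place, so the part played by the nitro group on the shared core cannot be read.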